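Replacing the Aryl Group of Compound 2

A few compounds are considered here, and "the series" means these few. Any claim that something is new, unique, unknown or untested is made for them only; others in the source may bear on it.

For the measured compounds named here, in a functional assay on the whole organism (Hindlimb, strain albino) with Mus musculus as the target, in the maximal electroshock model, with a stated time of 0.5 h (on this read-out lower numbers stand for an effect already at smaller amounts and higher numbers for an effect only at larger amounts of compound), compound 2 `COc1ccc(C2CC(Nc3nc4ccc(C)cc4s3)=NN2C(C)=O)cc1` gives 37.3 umol/kg as the lowest of the three numbers so far. Compound 3 `COc1ccc(C2CC(Nc3nc4ccc([N+](=O)[O-])cc4s3)=NN2C(C)=O)cc1` gives 145 umol/kg and compound 1 `Cc1ccc2nc(NC(=O)/C=C/OC3=CC=C3)sc2c1` gives 505 umol/kg on a different core. Compound 4 `CC(=O)N1N=C(Nc2nc3ccc(C)cc3s2)CC1OC1=CC=C1` differs from compound 2 at one place only, by a group of 5 heavy atoms (4 carbon, 1 oxygen; one four-membered non-aromatic ring of carbon only) in place of a group of 8 heavy atoms (7 carbon, 1 oxygen; one six-membered aromatic ring of carbon only), on a saturated ring carbon alone. Going by the values given here, the one measured step is a 3.9-fold higher number from compound 2 to compound 3 (0.59 log units; beyond the scatter) at another place, so it shows only that a single change can shift the number. Compound 1 carries the incoming group and gives 505 umol/kg on its different core, so a move towards a higher number is expected, though only a moderate one. The expected change is a 3.2-fold higher number from compound 2 to compound 4 (0.51 log units; beyond the scatter) as a rough estimate. Compound 4 is estimated at 120 umol/kg and expected to fall from 35 umol/kg to 400 umol/kg on this estimate.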

Compound 4, dose for half-maximal effect: 160 umol/kg
The estimate for compound 4 lay 1.3-fold (0.12 log units) below the measured number; the measured number falls inside the stated range.
By their numbers in this assay, from the lowest: compound 2; then compounds 3 and 4 (each within the scatter of the next); then compound 1.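

In this assay, the saturated ring carbon next to the ring nitrogen also proves sensitive: the group of 5 heavy atoms in place of 4-methoxyphenyl gives a 4.3-fold higher number from compound 2 to compound 4 (0.63 log units; beyond the scatter). The number therefore shifts at this place as well as on the aromatic carbon, and here 4-methoxyphenyl gives the lower number of the two groups. Nothing measured here explains the shift. The compounds shown leave open whether the aromatic ring, the methoxy group or the size of the group matters, and how a plain phenyl or a dimethylamine at this carbon would read.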